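A few compounds are considered here, and "the series" means these few. Any claim that something is new, unique, unknown or untested is made for them only; others in the source may bear on it.

In a functional assay on M14 cells (Homo sapiens) for inhibition, read by sulforhodamine B assay, with a stated time of 48 h (a higher number here means that more compound is tolerated, a lower number that less compound is tolerated), compound 1 `COc1cc(-c2nn(-c3cccc(NC(=O)Nc4ccc(Cl)c(Cl)c4)c3)cc2-c2ccncc2)ccc1Cl` gives 41200 nM, while compound 2 `COc1cc(-c2nn(-c3cccc(NC(=O)Nc4cccc(C(F)(F)F)c4)c3)cc2-c2ccncc2)ccc1Cl` gives 4650 nM. Among the measured compounds shown here, the single measured step, an 8.9-fold lower number from compound 1 to compound 2 (0.95 log units; beyond the scatter), came with 3-(trifluoromethyl)phenyl in place of 3,4-dichlorophenyl on an amide-type nitrogen. Of the two numbers, compound 2 stands lowest. Compound 3 `COc1cc(-c2nn(-c3cccc(NC(=O)c4ccccc4)c3)cc2-c2ccncc2)ccc1Cl` differs from compound 2 by phenyl in place of (3-(trifluoromethyl)phenyl)amino on a carbonyl carbon. For the measured compounds named here, no measured step touches this part in the same way: the step from compound 1 to compound 2 only exchanged one ring for another on the amide-type nitrogen, whereas here that nitrogen and its ring are removed altogether, so the expectation rests on little evidence and carries a wide range. For compound 3 the number is expected to rise to 15000 nM, somewhere between 3000 nM and 60000 nM. This corresponds to an expected step of a 3.2-fold higher number from compound 2 to compound 3 (0.51 log units; beyond the scatter).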

Compound 3, concentration lethal to 50% of the cells: > 100000 nM
Compound 3 was reported as a limit (the forecaster's own chance of this, stated with the estimate: 10%); at least 6.6-fold (0.82 log units) between middle value and limit.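

Compound 3 is reported in this assay only as a limit: the limit of > 100000 nM in this assay, at which 1 of the 3 values shown sits. Replacing the substituted phenylamino group on the carbonyl carbon with phenyl gives an at least 21-fold higher number from compound 2 to compound 3 (1.33 log units; beyond the scatter) and an at least 2.4-fold higher number from compound 1 to compound 3 (0.38 log units; beyond the scatter). The earlier step only exchanged one ring for another on the amide-type nitrogen, whereas these two steps show that removing that nitrogen together with its ring raises the number from either starting compound, so both point the same way.

The change removes the amino nitrogen, with the amide hydrogen, and the ring substituents at once, so the compounds shown cannot tell which of these accounts for the rise. An unsubstituted phenylamino group on the carbonyl carbon, or a 3-(trifluoromethyl)phenyl group attached directly to it, would separate the two.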